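A Flipped Ring Centre in a GCN2 Inhibitor Series

The source may report more compounds than this note shows. Statements on the series, on what has been measured and on what is new or still open speak of the compounds shown alone.

Compound 2, `COCCNC(=O)[C@H]1CC[C@@H](Nc2ncc3c(Br)nn(-c4ccc5ncccc5c4)c3n2)C1`, is measured in an assay on isolated protein for inhibition of eIF-2-alpha kinase GCN2 (Homo sapiens) (a higher number here means a weaker inhibitor, a lower number a stronger inhibitor), where compound 2 gives 61 nM. Going by the values given here, compound 2 is the only compound in this set with a numerical value; the other result is a limit. Compound 1, `COCCNC(=O)CCNc1ncc2c(Br)nn(-c3ccc4ncccc4c3)c2n1`, in this assay reaches only the limit of > 1000 nM, which is a boundary of the measurement and not a number, as noted in the limit of > 1000 nM in this assay, at which 1 of the 2 values shown sits.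

Compound 3, `COCCNC(=O)[C@H]1CC[C@H](Nc2ncc3c(Br)nn(-c4ccc5ncccc5c4)c3n2)C1`, keeps every atom and bond of compound 2. The difference is the two compounds have the same atoms and bonds and differ only in configuration as drawn: 1 of 2 stereo elements differ; a stereocentre at a saturated ring carbon is drawn R in compound 2 and S in compound 3. The amide-bearing arm and the amine attachment on the saturated ring therefore sit in a different spatial relation to one another, with nothing leaving and nothing entering.

Among the compounds with values here, no measured pair in this set changes only configuration, so there is no directly comparable step to lean on. A change of this kind is nevertheless expected to shift this assay, and the step from compound 2 to compound 3 is estimated at a 4.1-fold higher number from compound 2 to compound 3 (0.61 log units; beyond the scatter), toward weaker inhibition, although a result within the scatter cannot be excluded. On that basis compound 3 in this assay is expected to give about 250 nM, with a plausible range from 50 nM to 1200 nM.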

Compound 3, half-maximal inhibitory concentration: 144 nM
Estimate against measurement, compound 3: 1.7-fold (0.24 log units) above; measured number inside the range.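

In this assay, reversing the drawn configuration at one saturated ring carbon, which changes the three-dimensional arrangement of the same atoms, gives a 2.4-fold higher number from compound 2 to compound 3 (0.37 log units; beyond the scatter). This modest step is beyond the scatter, and it can be assigned to that single stereocentre because no atom or bond changes: the fact that compounds 2 and 3 differ only in the configuration as drawn The result also shows that this position tolerates either drawn configuration to a useful degree, since compound 3 still gives 144 nM, a measured number and not a limit.

On these data alone, the other stereocentre on the saturated ring is drawn the same way in compound 2 and compound 3, so the effect of reversing it, alone or together with the first, remains open. Also open, as far as these compounds go, is whether the same modest preference would hold if the amide-bearing arm were replaced by a carboxylic acid or a longer chain, since both compounds in this comparison carry the same arm.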